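Swapping piperidin-1-yl for dimethylamino on a shared core

A few compounds are considered here, and "the series" means these few. Any claim that something is new, unique, unknown or untested is made for them only; others in the source may bear on it.

Measured so far in an ADME assay on L6 cells (Rattus norvegicus) for cytotoxicity, with a stated time of 72 h (on this read-out lower numbers stand for stronger inhibition and higher numbers for weaker inhibition), are two compounds:
Compound 1 `CN(C)C12CC(OC(=O)/C=C/c3ccccc3)C(C(c3ccccc3)C1)C(c1ccccc1)C2` gives 3820 nM
Compound 2 `O=C(CN1CCCCC1)OC1CC2(N3CCCCC3)CC(c3ccccc3)C1C(c1ccccc1)C2` gives 60400 nM

Compound 2 has the higher number of the two, beyond the scatter from compound 1. Going to compound 3 `CN(C)C12CC(OC(=O)CN3CCCCC3)C(C(c3ccccc3)C1)C(c1ccccc1)C2` brings dimethylamino in place of piperidin-1-yl on a saturated ring carbon and nothing else: dimethylamino in place of piperidin-1-yl on a saturated ring carbon. Among the compounds with values here, no measured pair shows this change alone. Compound 1 also carries dimethylamino and stands at 3820 nM but has a different ester, so it is only a loose guide. A small move towards lower numbers, possibly within the scatter, is expected, with a 1.7-fold lower number from compound 2 to compound 3 (0.24 log units; within the scatter) as the estimated step in this assay for now. For compound 3 the expected value is 35000 nM as a middle estimate, with a range of 12000 nM to 100000 nM around it.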

Compound 3, half-maximal inhibitory concentration: 29300 nM
Estimate against measurement, compound 3: 1.2-fold (0.08 log units) above, within the range that was stated.
By their numbers in this assay, from the lowest: compound 1; then compound 3; then compound 2.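

In this assay, the swap of piperidin-1-yl for dimethylamino on the saturated ring carbon now stands alone, and it gives a modest step (a 2.1-fold lower number from compound 2 to compound 3 (0.31 log units; beyond the scatter)) that lies beyond the scatter. The change on the carbonyl carbon, (piperidin-1-yl)methyl in place of 2-phenylethenyl, gives the larger step (a 7.7-fold higher number from compound 1 to compound 3 (0.88 log units; beyond the scatter)). No measured evidence here explains either step and the sentence ends there.

The compounds shown leave open how a morpholin-4-yl ring or a primary amine would behave on that ring carbon. They also leave open whether the amine swap gives a similar step when the ester carries 2-phenylethenyl.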